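The source may report more compounds than this note shows. Statements on the series, on what has been measured and on what is new or still open speak of the compounds shown alone.

For the measured compounds named here, the three compounds measured so far share one core and differ only in the group on the aromatic nitrogen. Compound 1 `CCCCn1ccc2cc(/C(C)=C/C(=O)Nc3ccccc3OCCCC(=O)O)ccc21` carries a butyl there, and in an assay on Prostate gland for inhibition of steroid 5-alpha-reductase (Rattus norvegicus) (on this read-out higher numbers stand for weaker inhibition and lower numbers for stronger inhibition), compound 1 gives 43 nM. Compound 2 `CCCCCCn1ccc2cc(/C(C)=C/C(=O)Nc3ccccc3OCCCC(=O)O)ccc21` carries a hexyl, and in this assay compound 2 gives 77 nM. Compound 3 `CCC(C)n1ccc2cc(/C(C)=C/C(=O)Nc3ccccc3OCCCC(=O)O)ccc21` carries a sec-butyl, and in this assay compound 3 gives 67 nM. Compound 2 shows the highest of the three numbers, but every gap is small: a 1.8-fold higher number from compound 1 to compound 2 (0.25 log units; within the scatter) and a 1.1-fold lower number from compound 2 to compound 3 (0.06 log units; within the scatter) are both within the scatter, as is a 1.6-fold higher number from compound 1 to compound 3 (0.19 log units; within the scatter).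

Compound 4 `CCCCc1ccc(Cn2ccc3cc(/C(C)=C/C(=O)Nc4ccccc4OCCCC(=O)O)ccc32)cc1` is not yet measured. It differs from compound 2 by 4-butylphenyl in place of pentyl on a saturated chain carbon bound to an aromatic nitrogen. The measured steps replace one saturated chain with another and move the number only within the scatter; none of them brings in an aromatic ring, so they offer no direct guide to this change. The step is therefore expected to be no larger than the scatter, with wide uncertainty, giving a 1.3-fold lower number from compound 2 to compound 4 (0.11 log units; within the scatter) as the expected change. Compound 4 is estimated at 60 nM, with a range from 20 nM to 200 nM.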

Compound 4, half-maximal inhibitory concentration: 100 nM
Beside the measured number, compound 4's estimate is 1.7-fold (0.22 log units) below it; low and high end bracket the measured number.
By their numbers in this assay, from the lowest: compounds 1, 3, 2 and 4 (each within the scatter of the next, the first and the last beyond it).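

The group on the aromatic nitrogen can hold an aromatic ring as well as a saturated chain in this assay: the change from hexyl to 4-butylbenzyl gives a 1.3-fold higher number from compound 2 to compound 4 (0.11 log units; within the scatter), and the change from sec-butyl gives a 1.5-fold higher number from compound 3 to compound 4 (0.17 log units; within the scatter). Only the comparison with the butyl compound leaves the scatter, with a 2.3-fold higher number from compound 1 to compound 4 (0.37 log units; beyond the scatter), so the two ends of this small series can now be told apart, while compound 2 and compound 3 stay within the scatter of both. No independent measurement is available to account for this modest gap.

The compounds shown leave open what a plain benzyl group would give on the aromatic nitrogen, which would separate the ring from its butyl chain. They also leave open how a chain ending in an amine or a hydroxyl group would compare with these saturated chains.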